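The source may hold more compounds than are shown below. What is called first, only, known or untested is meant among the compounds shown, and "the series" means these compounds.

Measured so far:
compound 1, `Cc1ccc(COc2ccc(C(=O)NC(=S)Nc3ccc(C)c(-c4nc5ccccc5[nH]4)c3)cc2)cc1`: 11300 nM
compound 2, `Cc1ccc(NC(=O)NC(=O)c2ccc(OCc3cccc(C(F)(F)F)c3)cc2)cc1-c1nc2ccccc2[nH]1`: 9600 nM

Both compounds were tested in a functional assay on MNK45 cells (Homo sapiens) for inhibition, read by MTT assay, with a stated time of 48 h; a lower number here means a stronger inhibitor, a higher number a weaker inhibitor. Compound 1 gives 11300 nM and compound 2 gives 9600 nM. Compound 2 has the smaller of the two numbers, but the gap to compound 1 lies within the usual scatter of this assay, so the two cannot be told apart on these data. Both sit in the weak range.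

Compound 3, `Cc1ccc(NC(=O)NC(=O)c2ccc(OCc3ccc(F)cc3)cc2)cc1-c1nc2ccccc2[nH]1`, has not yet been measured in this assay. It differs from compound 2 in one place: 4-fluorophenyl in place of 3-(trifluoromethyl)phenyl on a saturated chain carbon bound to an oxygen on an aromatic ring. Within the data shown here, no measured pair here shows what such a change does, so the expectation rests only on the weak, closely matched numbers of compound 1 and compound 2. The step expected from compound 2 to compound 3 in this assay is a 1.0-fold higher number from compound 2 to compound 3 (0.02 log units; within the scatter), that is, no change beyond the scatter in either direction. Compound 3 is therefore estimated at 10000 nM, with a range from 4000 nM to 25000 nM.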

Compound 3, half-maximal inhibitory concentration: 240 nM
Estimate against measurement, compound 3: 42-fold (1.62 log units) above; measured number below the stated range.
By their numbers in this assay, from the lowest: compound 3; then compounds 2 and 1 (each within the scatter of the next).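

In this assay, the group on the saturated chain carbon bound to an oxygen on an aromatic ring proves able to change the result sharply: 4-fluorophenyl in place of 3-(trifluoromethyl)phenyl gives a 40-fold lower number from compound 2 to compound 3 (1.60 log units; beyond the scatter). Before this result, no step between compounds differing in one place could be read, so this is the first evidence that this position matters in this series. Nothing available explains why this single change has so large an effect.

The change alters two things at once, removing the trifluoromethyl group and adding a fluorine at a different ring position, so the compounds shown cannot separate the contribution of each. A plain phenyl, 3-fluorophenyl or 4-(trifluoromethyl)phenyl at the same place would help to tell these contributions apart.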